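From 4-aminobutyl to 2-aminoethyl: an open step

A few compounds are considered here, and "the series" means these few. Any claim that something is new, unique, unknown or untested is made for them only; others in the source may bear on it.

Three compounds sharing one core have so far been examined in a toxicity assay on cells (Macrophage, Homo sapiens) for inhibition, read by MTT assay; on this read-out lower numbers stand for stronger inhibition and higher numbers for weaker inhibition. For compound 1 `CN1CCN(CCCNc2nc(-c3ccc(Cl)cc3)nc3ccccc23)CC1` the entry reads "nd" (no result reported), so it offers no number for comparison. Compound 2 `NCCCCNc1nc(-c2ccc(Cl)cc2)nc2ccccc12` gives 13000 nM, while compound 3 `CN(C)CCCNc1nc(-c2ccc(F)cc2)nc2ccccc12` gives 63000 nM. Compound 2 therefore holds the lower of the two numbers, and its gap to compound 3 lies beyond the usual scatter. Among the compounds with values here, no two measured compounds differ in only one place, so the data contain no direct guide to the size of a single change.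

Compound 4 `NCCNc1nc(-c2ccc(Cl)cc2)nc2ccccc12` has yet to be measured in this assay. It departs from compound 2 in the side chain: amino in place of 2-aminoethyl on a saturated chain carbon, two bonds along the chain from a nitrogen on an aromatic ring. Put simply, (4-aminobutyl)amino gives way to (2-aminoethyl)amino. Within the data shown here, with no measured step to draw on, no shift beyond the scatter is expected, with only a slight lean towards a higher number. The expected change is a 1.2-fold higher number from compound 2 to compound 4 (0.09 log units; within the scatter). For compound 4 the estimated value is 16000 nM, with an expected range of 6000 nM to 45000 nM.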

Compound 4, half-maximal inhibitory concentration: 15000 nM
Compound 4: middle estimate off by 1.1-fold (0.03 log units), on the high side, and the stated range covers the measured number.
By their numbers in this assay, from the lowest: compounds 2 and 4 (each within the scatter of the next); then compound 3.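

In this assay the series now has its first measured step between compounds that differ in one place, and it reads a 1.2-fold higher number from compound 2 to compound 4 (0.06 log units; within the scatter) for amino in place of 2-aminoethyl on a saturated chain carbon, two bonds along the chain from a nitrogen on an aromatic ring. Within the data shown here, at this position, then, the (4-aminobutyl)amino and (2-aminoethyl)amino side chains cannot be told apart on this read-out, a point that the earlier compounds, with no pair differing in one place, could not settle. No measurement shown here offers an explanation for this result.

The compounds shown leave open whether the same holds for other chains on this core with the 4-chlorophenyl group kept in place, such as a (3-aminopropyl)amino chain, a longer chain ending in an amine, or a chain ending in a hydroxyl group or a carboxylic acid. They also leave open what a single change to the end of the chain would do, for example a dimethylamino group or a methylpiperazine in place of the primary amine on a chain of the same length.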